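The source may hold more compounds than are shown below. What is called first, only, known or untested is meant among the compounds shown, and "the series" means these compounds.

Measured compounds in a functional assay on MCF7 cells (Homo sapiens) for cytotoxicity, read by MTT assay, with a stated time of 48 h; on this read-out lower numbers stand for stronger inhibition and higher numbers for weaker inhibition:

- Compound 1, `C=C/C(C)=C/CC/C(C)=C/c1cc(C(=O)OC)co1`: compound 1 gives 28900 nM.
- Compound 2, `C=C/C(C)=C\CC/C(C)=C/c1cc(C(=O)Nc2ccc(C)cc2)co1`: compound 2 gives 65300 nM.
- Compound 3, `C=C/C(C)=C\CC/C(C)=C/c1cc(C(=O)N2CCN(C(c3ccccc3)c3ccccc3)CC2)co1`: compound 3 gives 26700 nM.

On these three numbers compound 1 stands second highest. Its nearest neighbour is compound 3, whose value lies within the usual scatter of compound 1's, so no order between the two can be read. Compound 2 is the furthest away, with a higher number that lies beyond the scatter, so compound 2 is the weaker of that pair in this assay.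

The next compound is compound 4, `C=C/C(C)=C\CC/C(C)=C/c1cc(C(=O)OC)co1`. Against compound 1 the change is the two compounds have the same atoms and bonds and differ only in configuration as drawn: 1 of 2 stereo elements differ; a double bond is drawn E in compound 1 and Z in compound 4. For the measured compounds named here, no pair of measured compounds isolates this change. Compounds 2 and 3 carry the same drawn configuration as compound 4 but differ in the ester part as well, so they give no clean comparison; their two values bracket the value of compound 1 rather than pointing one way.

With nothing in the measured set to anchor a direction, the step from compound 1 to compound 4 is expected to be small, a 1.0-fold higher number from compound 1 to compound 4 (0.02 log units; within the scatter), and not beyond the scatter. Compound 4 is therefore estimated at 30000 nM in this assay, with a range from 14000 nM to 65000 nM.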

Compound 4, half-maximal inhibitory concentration: 75400 nM
For compound 4 the middle estimate is 2.5-fold (0.40 log units) below the measured one, and the stated range ends below it.
By their numbers in this assay, from the lowest: compounds 3 and 1 (each within the scatter of the next); then compounds 2 and 4 (each within the scatter of the next).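

In this assay the configuration of this double bond registers on its own, with a 2.6-fold higher number from compound 1 to compound 4 (0.42 log units; beyond the scatter), so the drawn E form goes with the lower number in this pair. The step can be placed on that double bond alone because nothing else separates the two compounds: the fact that compounds 1 and 4 differ only in the configuration as drawn

With the Z double bond held, the carbonyl substituent gives no readable order, with a 1.2-fold higher number from compound 2 to compound 4 (0.06 log units; within the scatter) for methoxy in place of (4-methylphenyl)amino on a carbonyl carbon, so in this pair the change at that carbonyl does not register beyond the scatter.

The compounds shown leave open whether the same configuration step holds with an amide on that carbonyl as it does with the methyl ester. Going by these compounds, what a carboxylic acid or a longer alkyl ester would give at that carbonyl, with either configuration of the double bond, also stays open.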